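From Methoxy to Chloro: Expecting the Potency of Compound 4

This account rests on a few compounds, and the source may have more. Where it says the series, first, only, none or still open, it means among the compounds named here.

Measured so far:
Compound 1 `COc1ccc(NC(=O)CCCCCCCSc2nnc(Cc3nn(C)c(=O)c4ccccc34)n2C)cc1` gives 3900 nM.
Compound 2 `CN(C(=O)CSc1nnc(Cc2nn(C)c(=O)c3ccccc23)n1C)c1ccc(Cl)cc1Cl` gives > 30000 nM, which is a limit of the assay rather than a number.
Compound 3 `Cn1c(Cc2nn(C)c(=O)c3ccccc23)nnc1S(=O)(=O)CCCCCCCC(=O)Nc1ccc(Br)cc1Br` gives 1400 nM.

All three were tested in an assay on isolated protein (Mus musculus) for inhibition of IL15-IL15 receptor (Homo sapiens), read by resazurin assay, with stated times of 30 min and 2.5 days; on this read-out higher numbers stand for weaker inhibition and lower numbers for stronger inhibition. Of the two numbers shown, compound 1 stands highest, meaning the weaker of the two; compound 3 sits lower, and that gap lies beyond the usual scatter. For compound 2 the assay reports only a limit, (the limit of > 30000 nM in this assay, at which 1 of the 3 values shown sits), so it offers no number to compare.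

Compound 4 `Cn1c(Cc2nn(C)c(=O)c3ccccc23)nnc1SCCCCCCCC(=O)Nc1ccc(Cl)cc1` has not yet been measured. It differs from compound 1 in one place: chloro in place of methoxy on an aromatic carbon. Among the compounds with values here, since no pair of measured compounds differs by just this change, the size of the step is open. Chloro in place of methoxy on an aromatic carbon is a small change, so a modest step is expected, most likely toward stronger inhibition or none beyond the scatter; the step from compound 1 to compound 4 is estimated as a 1.6-fold lower number from compound 1 to compound 4 (0.19 log units; within the scatter). Compound 4 is therefore expected to give about 2500 nM, within a range of 900 nM to 7000 nM.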

Compound 4, half-maximal inhibitory concentration: 800 nM
Compound 4: middle estimate off by 3.1-fold (0.49 log units), on the high side, outside the stated range (below it).
By their numbers in this assay, from the lowest: compounds 4 and 3 (each within the scatter of the next); then compound 1. At a limit, above all of these: compound 2.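

With the rest of the molecule unchanged, chloro in place of methoxy on this aromatic carbon gives a 4.9-fold lower number from compound 1 to compound 4 (0.69 log units; beyond the scatter) and so stronger inhibition. The earlier compounds shown here differ from one another in several places at once, whereas this pair shows that this single position, para to a large group, can by itself move the number beyond the usual scatter. Nothing measured here explains why this change has that effect.

A plain hydrogen, fluoro or an amine at this position would help tell whether the step comes from gaining chloro or from losing methoxy. On these data alone, whether the same change gives a step of similar size on a shorter or longer chain also remains open.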